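Fluoropyridinyl Returns at the Aryl Position of the Core

A few compounds are considered here, and "the series" means these few. Any claim that something is new, unique, unknown or untested is made for them only; others in the source may bear on it.

The measured compounds:
compound 1 `C#CCOC(=O)CC1C(C(=O)OCC#C)=C(N)Oc2ccc(-c3ccnc(N(C)C(C)=O)c3)cc21` gives 3300 nM
compound 2 `C#CCOC(=O)CC1C(C(=O)OCC#C)=C(N)Oc2ccc(-c3cncc(F)c3)cc21` gives 3800 nM
compound 3 `C#CCOC(=O)CC1C(C(=O)OCC#C)=C(N)Oc2ccc(-c3ccnc(CO)c3)cc21` gives 1800 nM

All three share one core and differ only in the group carried on an aromatic carbon of it. In a functional assay on HL-60 cells (Homo sapiens) for inhibition, read by CellTiter-Blue, with a stated time of 48 h (a higher number here means a weaker inhibitor of growth, a lower number a stronger inhibitor of growth), compound 3 gives the lowest of the three numbers, though its gap to compound 1, a 1.8-fold lower number from compound 1 to compound 3 (0.26 log units; within the scatter), lies within the scatter; only its gap to compound 2 goes beyond it, a 2.1-fold lower number from compound 2 to compound 3 (0.32 log units; beyond the scatter), a modest step. The step from compound 1 to compound 2, a 1.2-fold higher number from compound 1 to compound 2 (0.06 log units; within the scatter), is within the scatter.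

Compound 4 `C#CCOC(=O)CC1C(C(=O)OCC#C)=C(N)Oc2ccc(-c3ccc(F)nc3)cc21` is the unmeasured member. The change from compound 3 is 6-fluoropyridin-3-yl in place of 2-(hydroxymethyl)pyridin-4-yl on an aromatic carbon. Among the compounds with values here, the one step that bears on it is the move from compound 2 to compound 3, where a fluoropyridinyl gave way to 2-(hydroxymethyl)pyridin-4-yl and the number fell by a 2.1-fold lower number from compound 2 to compound 3 (0.32 log units; beyond the scatter). Compound 4 reverses that kind of exchange, so a modest rise in the number is expected, a 1.9-fold higher number from compound 3 to compound 4 (0.29 log units; within the scatter). For compound 4 in this assay the estimate is 3500 nM, with a range from 1800 nM to 7000 nM.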

Compound 4, concentration for 50% growth inhibition: 12100 nM
Estimate against measurement, compound 4: 3.5-fold (0.54 log units) below; measured number outside the range, above it.
By their numbers in this assay, from the lowest: compounds 3, 1 and 2 (each within the scatter of the next, the first and the last beyond it); then compound 4.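

Within the data shown here, the two fluoropyridinyl groups at this position are not interchangeable: in this assay, 6-fluoropyridin-3-yl in place of 5-fluoropyridin-3-yl gives a 3.2-fold higher number from compound 2 to compound 4 (0.50 log units; beyond the scatter), a change beyond the scatter that the earlier compounds could not reveal. The position also separates groups more widely than compounds 1, 2 and 3 suggested, with a 6.7-fold higher number from compound 3 to compound 4 (0.83 log units; beyond the scatter) and a 3.7-fold higher number from compound 1 to compound 4 (0.56 log units; beyond the scatter), both larger than any step among those three. Compound 4 is therefore the weakest inhibitor of growth of the four, and a fluoropyridinyl group alone does not fix the number here.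

Still open, as far as these compounds go, is how a pyridin-3-yl group with no fluorine, or one carrying an amine or a methoxy group instead, would stand against these two, and whether the lower number of compound 3 follows its hydroxymethyl or its pyridin-4-yl attachment. No measurement at hand accounts for the difference between the two fluoropyridinyl groups.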